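The source may hold more compounds than are shown below. What is called first, only, known or untested is meant among the compounds shown, and "the series" means these compounds.

Among the measured compounds shown here, compound 2 `CC(=O)Nc1cccc(C2CCN(CCCn3c(-c4ccc(F)cc4)nc4ccccc43)CC2)c1` stands at the upper end of the two numbers measured so far. In an assay for displacement of a labelled ligand from melanin-concentrating hormone receptor 1 (Homo sapiens), read by fluorescence (a lower number here means a stronger inhibitor, a higher number a weaker inhibitor), compound 2 gives 56 nM, while compound 1 `COc1ccc(-c2nc3ccccc3n2CCCN2CCC(c3cccc(NC(C)=O)c3)CC2)cc1` gives 9 nM. For the measured compounds named here, the single measured step, a 6.2-fold higher number from compound 1 to compound 2 (0.79 log units; beyond the scatter), is the only one that touches the group sitting para to the large group on the shared core, and it lies beyond the scatter. Compound 3 `CC(=O)Nc1cccc(C2CCN(CCCn3c(-c4ccc(C#N)cc4)nc4ccccc43)CC2)c1` keeps that core and differs from compound 2 only in cyano in place of fluoro on an aromatic carbon. Going by the values given here, no measured step exchanges fluoro for cyano, so the step from compound 1 to compound 2 bears on it only in showing that a change at this carbon can move the number by a modest amount. Whether cyano will read more like methoxy or more like fluoro cannot be decided from two compounds, so the estimate sits between them and leans toward the lower number. The step is therefore expected to be a 1.9-fold lower number from compound 2 to compound 3 (0.27 log units; within the scatter). Compound 3 is estimated to give 30 nM in this assay, with a range from 8 nM to 120 nM.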

Compound 3, half-maximal inhibitory concentration: 16 nM
Compound 3: the middle estimate sits 1.9-fold (0.27 log units) above what was measured, within the range that was stated.
By their numbers in this assay, from the lowest: compounds 1 and 3 (each within the scatter of the next); then compound 2.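

In this assay, the change from 4-fluorophenyl to 4-cyanophenyl gives a 3.5-fold lower number from compound 2 to compound 3 (0.54 log units; beyond the scatter), so fluoro in compound 2 now differs beyond the scatter from a second group at this aromatic carbon, not only from methoxy. The exchange of methoxy for cyano gives a 1.8-fold higher number from compound 1 to compound 3 (0.25 log units; within the scatter), which means that compound 1 and compound 3 cannot be told apart in this assay, although their groups differ in name and in atoms. Among these three compounds, therefore, fluoro is the one group that stands apart, and nothing available accounts for this difference.

The compounds shown leave open where an amine, a carboxylic acid or a trifluoromethyl group at this carbon would fall relative to these three values, and whether a plain hydrogen would read closer to fluoro or to the other two groups. They also leave open whether the exchange of fluoro for cyano would keep its size if another part of the shared core were changed.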